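This account rests on a few compounds, and the source may have more. Where it says the series, first, only, none or still open, it means among the compounds named here.

In a functional assay for antagonist activity at Alpha-1A adrenergic receptor (Oryctolagus cuniculus) (a higher number here means weaker binding, a lower number tighter binding), compound 1 `CN(C)C(=O)c1cccnc1NCCCN1CCN(c2ccccc2)CC1` gives 6.31 nM. Going by the values given here, compound 2 `CN(C)C(=O)c1cccnc1NCCCN1CCN(c2ccccc2C2CC2)CC1` gives 0.631 nM in this assay, and the only measured step, a 10-fold lower number from compound 1 to compound 2 (1.00 log units; beyond the scatter), is the sole guide so far. Compound 2 thus stands at the lowest number of the two, with compound 1 as its nearest neighbour.

Compound 3 `COc1ccc(N2CCN(CCCNc3ncccc3C(=O)N(C)C)CC2)c(OC)c1` is not yet measured in this assay. It differs from compound 2 by 2,4-dimethoxyphenyl in place of 2-cyclopropylphenyl on an amine nitrogen in a ring. Among the compounds with values here, no measured step covers this exchange; the step from compound 1 to compound 2 bears on it only in that the cyclopropyl, whose arrival went with that step, now leaves, while the two methoxy groups arriving have no precedent. For compound 3 a move back toward compound 1 is therefore expected, a 4.0-fold higher number from compound 2 to compound 3 (0.60 log units; beyond the scatter), though with wide uncertainty. Compound 3 is estimated at 2.5 nM in this assay, within the range 0.6 nM to 10 nM.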

Compound 3, dissociation constant: 31.6 nM
The estimate for compound 3 lay 13-fold (1.10 log units) below the measured number; the whole stated range lies below it.
By their numbers in this assay, from the lowest: compound 2; then compound 1; then compound 3.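

Substitution on the phenyl at this place on the amine nitrogen does not move the number in one direction in this assay: the series now shows a 5.0-fold higher number from compound 1 to compound 3 (0.70 log units; beyond the scatter), whereas the cyclopropyl gave a 10-fold lower number from compound 1 to compound 2 (1.00 log units; beyond the scatter). The exchange of one substituted aryl group for the other is the largest change seen so far, with a 50-fold higher number from compound 2 to compound 3 (1.70 log units; beyond the scatter), so compound 1, with its unsubstituted phenyl, sits in value terms inside the span set by the two substituted groups. No evidence at hand accounts for the opposite directions of these two changes.

From the compounds shown here alone, it remains open which of the two methoxy groups goes with the higher number, or whether both are needed. A phenyl bearing a single methoxy, or a methyl or chlorine in place of the cyclopropyl, would help to separate these readings.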